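This account rests on a few compounds, and the source may have more. Where it says the series, first, only, none or still open, it means among the compounds named here.

Working notes on the series, measured in a functional assay, with a stated time of 20 min; a higher number here means a weaker inhibitor, a lower number a stronger inhibitor.

Compound 1 `CSc1nc(-c2cccs2)c(C#N)c(=O)n1C` gives 71 ug/mL in this assay. Compound 2 `Cn1c(NN)nc(-c2ccco2)c(C#N)c1=O` gives 64 ug/mL in this assay. Compound 3 `CCOC(=O)c1cnn(-c2nc(-c3cccs3)c(C#N)c(=O)n2C)c1N` gives 79 ug/mL in this assay. Compound 3 carries the highest of the three numbers, but the gap to compound 1 and the gap to compound 2 both lie within the scatter, so the three compounds are not separated from one another by these data.

Compound 4 `CCOC(=O)c1cnn(-c2nc(-c3ccc(N(C)C)cc3)c(C#N)c(=O)n2C)c1N` has not been measured. Relative to compound 3 the change is 4-(dimethylamino)phenyl in place of thiophen-2-yl on an aromatic carbon. Among the compounds with values here, no pair of measured compounds shows this change, so there is no measured step on which to rest a direction. The three measured values sit close together despite their different aryl groups, so the expected step from compound 3 to compound 4 is a 1.1-fold lower number from compound 3 to compound 4 (0.02 log units; within the scatter), that is, nothing beyond the scatter in either direction. For compound 4 the estimate in this assay is 75 ug/mL, with a range from 35 ug/mL to 160 ug/mL.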

Compound 4, half-maximal inhibitory concentration: 98 ug/mL
Compound 4: middle estimate off by 1.3-fold (0.12 log units), on the low side, within the range that was stated.
By their numbers in this assay, from the lowest: compounds 2, 1, 3 and 4 (each within the scatter of the next).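

Among the compounds shown, only compound 3 and compound 4 differ in one place. On the aromatic carbon ortho to a cyano group, 4-(dimethylamino)phenyl in place of thiophen-2-yl gives a 1.2-fold higher number from compound 3 to compound 4 (0.09 log units; within the scatter) in this assay. At this position, therefore, this assay does not separate the larger six-membered aromatic ring of carbon only from the five-membered aromatic ring with its hetero atom. No measurement bears on why the two groups are not separated.

This single step swaps the ring and adds the dimethylamino group together, so it leaves their separate contributions unresolved. Also open, from the compounds shown here alone, is whether an unsubstituted phenyl, or a phenyl carrying a carboxylic acid in place of the dimethylamino group, would move the number beyond the scatter.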